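The compounds below may be only part of what the source reports. "The series", "measured", "known", "first", "only" and "open" are said of these compounds alone.

Among the measured compounds shown here, compound 2 `CN(CCCN)C[C@H]1O[C@@H](n2cnc3c(N)ncnc32)[C@H](O)[C@@H]1O` gives 500000 nM in an assay on isolated protein for inhibition of S-adenosylmethionine decarboxylase proenzyme (Homo sapiens) (a higher number here means a weaker inhibitor, a lower number a stronger inhibitor), the highest of the two numbers known; compound 1 `CN(CCC(=O)NN)C[C@H]1O[C@@H](n2cnc3c(N)ncnc32)[C@H](O)[C@@H]1O` gives 1500 nM, and the step of a 330-fold higher number from compound 1 to compound 2 (2.52 log units; beyond the scatter) is large. Compound 3 `C[S+](C)C[C@H]1O[C@@H](n2cnc3c(N)ncnc32)[C@H](O)[C@@H]1O` differs from compound 2 in one place: a group of 3 heavy atoms (2 carbon, 1 sulfur; no ring) in place of a group of 6 heavy atoms (4 carbon, 2 nitrogen; no ring), on a saturated chain carbon bound to a saturated ring carbon. For the measured compounds named here, no measured step covers this kind of change, so the only guide is that both replacement and starting point sit on the same chain carbon. For compound 3 a step of a 10-fold lower number from compound 2 to compound 3 (1.00 log units; beyond the scatter) toward a lower number is expected in this assay. Compound 3 is thus estimated at 50000 nM, within 5000 nM to 500000 nM.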

Compound 3, half-maximal inhibitory concentration: 5000 nM
Beside the measured number, compound 3's estimate is 10-fold (1.00 log units) above it, within the range that was stated.
By their numbers in this assay, from the lowest: compound 1; then compound 3; then compound 2.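

Replacing the (3-aminopropyl)(methyl)amino group on this chain carbon gives a 100-fold lower number from compound 2 to compound 3 (2.00 log units; beyond the scatter) in this assay, so a low number here does not depend on that long amine chain. The smaller sulfur group with a net charge of +1 still falls short of the hydrazide-bearing chain of compound 1, with a 3.3-fold higher number from compound 1 to compound 3 (0.52 log units; beyond the scatter) as a modest step. No measurement offers a reason for either step. Compound 3 loses the chain and gains the charge together, so the two effects cannot be separated. On these data alone, how a dimethylamino group or a carboxylic acid would behave on this chain carbon remains open.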